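Aryl Swaps on a Shared Core at the Free Fatty Acid Receptor

A few compounds are considered here, and "the series" means these few. Any claim that something is new, unique, unknown or untested is made for them only; others in the source may bear on it.

Three compounds share a core and differ only in the aromatic group attached to it. In a functional assay on CHO cells for agonist activity at Free fatty acid receptor 1 (Homo sapiens), read by FLIPR and calcium flux, in the presence of a further agent that is not named here (on this read-out higher numbers stand for an effect only at larger amounts of compound and lower numbers for an effect already at smaller amounts), compound 1 `COc1cccc(-c2noc(COc3ccc(CCC(=O)O)cc3)n2)c1` gives 2670 nM, compound 2 `O=C(O)CCc1ccc(OCc2nc(-c3cccc(Br)c3)no2)cc1` gives 1260 nM, and compound 3 `O=C(O)CCc1ccc(OCc2nc(-c3cccs3)no2)cc1` gives 2570 nM. Compound 3 thus stands second highest of the three numbers: against compound 1 it sits within the scatter, while a 2.0-fold higher number from compound 2 to compound 3 (0.31 log units; beyond the scatter) lies beyond it.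

Compound 4 `O=C(O)CCc1ccc(OCc2nc(-c3ccc(Cl)cc3)no2)cc1` carries the change (4-chlorophenyl in place of thiophen-2-yl on an aromatic carbon). Going by the values given here, two measured steps bear on this exchange. The step of a 1.0-fold lower number from compound 1 to compound 3 (0.02 log units; within the scatter) shows that a methoxy-bearing phenyl and the thiophene give indistinguishable numbers, whereas a 2.0-fold higher number from compound 2 to compound 3 (0.31 log units; beyond the scatter) shows that a halogen-bearing phenyl gives a modestly lower number than the thiophene. Since compound 4 also carries a halogen-bearing phenyl, a modest step towards lower numbers in this assay is expected, close to what compound 2 shows at 1260 nM.

For compound 4 a value of 1400 nM is estimated, with a range from 600 nM to 3200 nM, meaning an expected step of a 1.8-fold lower number from compound 3 to compound 4 (0.26 log units; within the scatter).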

Compound 4, half-maximal effective concentration: 540 nM
Beside the measured number, compound 4's estimate is 2.6-fold (0.41 log units) above it, and the stated range ends above it.
By their numbers in this assay, from the lowest: compound 4; then compound 2; then compounds 3 and 1 (each within the scatter of the next).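

At this position, on the ring carbon between two ring nitrogen atoms, the aromatic group moves the number in this assay further than any earlier step showed: a 4.8-fold lower number from compound 3 to compound 4 (0.68 log units; beyond the scatter) and a 4.9-fold lower number from compound 1 to compound 4 (0.69 log units; beyond the scatter) both set 4-chlorophenyl clearly apart from two groups that had given indistinguishable numbers. A halogen on the phenyl ring is also not the whole story, as a 2.3-fold lower number from compound 2 to compound 4 (0.37 log units; beyond the scatter) separates 4-chlorophenyl from 3-bromophenyl and leaves compound 4 with the lowest number of the four. Nothing available here explains the size of these steps.

The compounds shown leave open whether the halogen or its place on the phenyl ring accounts for the gap between compound 2 and compound 4, which a 3-chlorophenyl or a 4-bromophenyl group would help to separate. From the compounds shown here alone, how a nitrile or an amine in place of the chlorine would read also remains open.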